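Cytotoxicity notes on a fused bicyclic series

This account rests on a few compounds, and the source may have more. Where it says the series, first, only, none or still open, it means among the compounds named here.

Measured compounds:
- compound 1, `Fc1ccc(-c2nn3c(NC4CCCC4)cccc3c2-c2cc(NC3CCCC3)ncn2)cc1`, > 40000 nM
- compound 2, `Nc1nc(-c2c(-c3ccc(F)cc3)nn3c(NC4CCCC4)cccc23)c[nH]1`, "not determined" (no result reported)
- compound 3, `Fc1ccc(-c2nn3c(NC4CCCC4)cccc3c2-c2cccnc2NC2CCCC2)cc1`, "not determined" (no result reported)

In an ADME assay on Vero cells (Chlorocebus sabaeus) for cytotoxicity (a lower number here means that less compound is tolerated, a higher number that more compound is tolerated), compound 1 gives > 40000 nM, which is a limit of the assay and not a number. For compound 2 the entry in this assay is "not determined" (no result reported), so compound 2 stands on no single number. Compound 3 likewise has only "not determined" (no result reported) in this assay. For the measured compounds named here, the only evidence in the set is therefore (the limit of > 40000 nM in this assay, at which 1 of the 3 values shown sits); no step between measured compounds can be read, and nothing is known about how compound 2 compares with compound 1.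

The unmeasured compound 4, `Fc1ccc(-c2nn3c(NC4CCCC4)cccc3c2-c2cc[nH]n2)cc1`, differs from compound 2 by 1H-pyrazol-3-yl in place of 2-amino-1H-imidazol-4-yl on an aromatic carbon. Going by the values given here, with no measured step in this assay to lean on, the step from compound 2 to compound 4 is expected to be small, with no direction beyond the scatter, and the likeliest outcome is that compound 4 also sits at the assay limit, as compound 1 does with the limit of > 40000 nM in this assay, at which 1 of the 3 values shown sits.

Compound 4 is estimated at 40000 nM in this assay, with a range from 20000 nM to 80000 nM.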

Compound 4, half-maximal cytotoxic concentration: 14000 nM
Compound 4: the middle estimate sits 2.9-fold (0.46 log units) above what was measured; measured number outside the range, below it.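

In this assay, for the compounds shown here, compound 4 gives 14000 nM; compound 2 has no single number there, and no step between compound 2 and compound 4 can be read. The compounds shown leave open how 1H-pyrazol-3-yl and 2-amino-1H-imidazol-4-yl compare on the shared core in this assay.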